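A few compounds are considered here, and "the series" means these few. Any claim that something is new, unique, unknown or untested is made for them only; others in the source may bear on it.

In a functional assay on the whole organism for inhibition, with Rattus norvegicus as the target, read by paw edema, at a dose of 100 mg/kg by the oral route (on this read-out lower numbers stand for less inhibition and higher numbers for more inhibition at the one dose given (going by the name of the read-out)), two compounds have been measured so far. Compound 1, `O=C(NCc1ccccc1)c1c(O)c2cccnc2n(-c2ccccc2)c1=O`, gives 1.6%, and compound 2, `O=C(Nc1ccccc1)c1c(O)c2cccnc2n(-c2ccccc2)c1=O`, gives 4.6%. The one step between them, a number 3 percentage points higher from compound 1 to compound 2 (within the scatter), is too small to count as a real change, so on the numbers shown compound 2 and compound 1 lie within the scatter of each other, both close to no inhibition.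

Compound 3, `COc1cccc(NC(=O)c2c(O)c3cccnc3n(-c3ccccc3)c2=O)c1`, differs from compound 2 in one place: methoxy in place of hydrogen on an aromatic carbon. Among the compounds with values here, no measured step covers this kind of change; the only step seen so far swapped phenyl for benzyl on an amide-type nitrogen, and it stayed within the scatter. With nothing pointing either way, the expected step for compound 3 is a number 1.4 percentage points higher from compound 2 to compound 3 (within the scatter), none beyond the scatter. Compound 3 is therefore estimated at 6%, with a likely range from -6% to 22%.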

Compound 3, a percentage reported as inhibition, in the whole organism at one dose (the size of the read-out at that dose, not a potency): 5.7%
For compound 3 the middle estimate is 0.3 percentage points above the measured one; the range from low to high includes it.
By their numbers in this assay, from the lowest: compounds 1, 2 and 3 (each within the scatter of the next).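

In this assay, adding methoxy to an aromatic carbon of the anilide's phenyl ring, meta to a large group, gives a number 1.1 percentage points higher from compound 2 to compound 3 (within the scatter) and so does not measurably change the read-out at this position. Replacing benzyl on the amide-type nitrogen with 3-methoxyphenyl gives a number 4.1 percentage points higher from compound 1 to compound 3 (within the scatter) and likewise does not separate the two compounds, so this substituted ring shows no gain over either of the simpler groups. Nothing available explains this flat result.

One methoxy group at one place on this ring cannot show whether the position can affect paw edema at all. An amine, a carboxylic acid or a longer chain such as butoxy at this same carbon, or methoxy on another carbon of the ring, remains an open case.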